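This account rests on a few compounds, and the source may have more. Where it says the series, first, only, none or still open, it means among the compounds named here.

Measured compounds:
compound 1 `O=C(Nc1cccc2ncccc12)N1CCN(c2ccccc2C(F)(F)F)CC1` with 5260 nM
compound 2 `O=C(Nc1ccncc1)N1CCN(c2ccccc2C(F)(F)F)CC1` with 1160 nM

Both numbers come from an assay on isolated protein with transient receptor potential cation channel subfamily V member 1 (Homo sapiens) as the target; a lower number here means that less compound is needed, a higher number that more compound is needed for the effect. Of the two, compound 2 gives the lower number; the nearest is compound 1, whose number is higher by a gap beyond the usual scatter. Compound 2 is thus the stronger of the two measured compounds.

Compound 3 `O=C(Nc1cccnc1)N1CCN(c2ccccc2C(F)(F)F)CC1` has not been measured. It differs from compound 2 in one place: pyridin-3-yl in place of pyridin-4-yl on an amide-type nitrogen. The two compounds are built from the same atoms, joined differently, so the change keeps the size of the group and moves only where the ring nitrogen sits.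

Going by the values given here, no measured pair shows the effect of this kind of change, so there is nothing in the data to set its size from. A shift of the ring nitrogen in a group of this size is often a modest change, and the expectation is a small rise in this assay, possibly within the scatter. For compound 3 the estimated step is a 1.9-fold higher number from compound 2 to compound 3 (0.28 log units; within the scatter). Compound 3 is therefore expected to give about 2200 nM, with a range from 600 nM to 8000 nM.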

Compound 3, half-maximal effective concentration: 618 nM
Compound 3: the middle estimate sits 3.6-fold (0.55 log units) above what was measured; the range from low to high includes it.
By their numbers in this assay, from the lowest: compounds 3 and 2 (each within the scatter of the next); then compound 1.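

Moving the ring nitrogen, so that pyridin-3-yl takes the place of pyridin-4-yl on the amide-type nitrogen, gives in this assay a 1.9-fold lower number from compound 2 to compound 3 (0.27 log units; within the scatter), and the two compounds therefore cannot be told apart in this assay. This is the first pair shown that differs in only one place, and it gives a first direct reading of this position: for these two pyridine groups, where the ring nitrogen sits makes no difference that can be separated from the ordinary variation between repeated measurements. No supporting measurement bears on this result, so the data offer no explanation for it.

The pair leaves open whether the same holds for pyridin-2-yl, the remaining placement of the ring nitrogen, and whether a ring nitrogen matters at all, a question that a plain phenyl group at the same place could address. It also says nothing about larger changes at this position, such as a pyridine ring carrying a methoxy group or a chlorine atom, or about replacing the trifluoromethyl group elsewhere on the shared core.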